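Chloro to hydrogen: expectation for compound 3

This account rests on a few compounds, and the source may have more. Where it says the series, first, only, none or still open, it means among the compounds named here.

Compound 2 `CCOC(=O)c1c(-c2ccc(Cl)cc2)n(-c2ccc(C(=O)NNC(=O)CO[N+](=O)[O-])cc2)[nH]c1=O` gives 6.43% in a functional assay on the whole organism (strain Wistar) for inhibition, with Rattus norvegicus as the target, read by paw edema, with stated times of 3 h and 1 h, at a dose of 6 mg/kg by the oral route (on this read-out lower numbers stand for less inhibition and higher numbers for more inhibition at the one dose given (going by the name of the read-out)), the lowest of the two numbers measured; compound 1 `CCOC(=O)c1c(-c2ccc([N+](=O)[O-])cc2)n(-c2ccc(C(=O)NNC(=O)CO[N+](=O)[O-])cc2)[nH]c1=O` gives 22.2%. Within the data shown here, the only measured step, a number 15.8 percentage points lower from compound 1 to compound 2 (beyond the scatter), comes from chloro in place of nitro on an aromatic carbon. Compound 3 `CCOC(=O)c1c(-c2ccccc2)n(-c2ccc(C(=O)NNC(=O)CO[N+](=O)[O-])cc2)[nH]c1=O` differs from compound 2 by hydrogen in place of chloro on an aromatic carbon. Among the measured compounds shown here, no measured step exchanges chloro for hydrogen, so nothing bears directly on this change. Compound 3 is expected to stay close to its neighbour, with a number 0.6 percentage points higher from compound 2 to compound 3 (within the scatter) not beyond the scatter. The estimate for compound 3 is 7%, from 0% to 18%.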

Compound 3, a percentage reported as inhibition, in the whole organism at one dose (the size of the read-out at that dose, not a potency): 59.6%
Compound 3: middle estimate off by 52.6 percentage points, on the low side; measured number outside the range, above it.
By their numbers in this assay, from the lowest: compound 2; then compound 1; then compound 3.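

In this assay the change to hydrogen at this position gives a number 53.2 percentage points higher from compound 2 to compound 3 (beyond the scatter) when chloro leaves and a number 37.4 percentage points higher from compound 1 to compound 3 (beyond the scatter) when nitro leaves. Compound 3, with plain phenyl, therefore stands highest of the three, so neither substituent tried here matches hydrogen on this ring. Nothing measured on these compounds accounts for the size of these steps. From the compounds shown here alone, whether an amine, a methoxy group or a carboxylic acid in this place would stay near compound 3 or fall towards compound 2 remains open, as does whether the order holds at other doses.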